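Chloro for amino on the shared core: two pairs

A few compounds are considered here, and "the series" means these few. Any claim that something is new, unique, unknown or untested is made for them only; others in the source may bear on it.

Compound 1 `CC1(C)[C@@H](Cn2nnc3c(Cl)nc(N)nc32)CC[C@@]1(C)CO` and compound 2 `CC1(C)[C@@H](Cn2nnc3c(N)nc(N)nc32)CC[C@@]1(C)CO` share a core and differ only in one group. In an ADME assay on L1210/0 cells (Mus musculus) for cytotoxicity, with a stated time of 48 h (on this read-out higher numbers stand for weaker inhibition and lower numbers for stronger inhibition), compound 1 gives 44600 nM. Compound 2 reaches only the limit of this assay, > 200000 nM, and no number. The change from compound 2 to compound 1 is chloro in place of amino on an aromatic carbon, and it brings an at least 4.4-fold lower number from compound 2 to compound 1 (0.65 log units; beyond the scatter). This rests on (the limit of > 200000 nM in this assay, at which 2 of the 3 values shown sit), so the size of the step is known only as a lower bound.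

Compound 3 `Nc1nc(N)c2ncn([C@H]3CCCC[C@H]3CO)c2n1` carries a different core, and the difference between the two cores is not broken down here. In this assay compound 3 also reaches the limit, > 200000 nM, so only a bound is known for it.

Compound 4 `Nc1nc(Cl)c2ncn([C@H]3CCCC[C@H]3CO)c2n1` is not yet measured in this assay. It stands to compound 3 as compound 1 stands to compound 2: the change is chloro in place of amino on an aromatic carbon, the same kind of change in the same described place, with an amino group leaving and a chloro group entering. Among the measured compounds shown here, the only measured pair on this change is compound 2 to compound 1, with an at least 4.4-fold lower number from compound 2 to compound 1 (0.65 log units; beyond the scatter), on a different core, and compound 3 starts from a limit rather than a number. The expectation for compound 4 is therefore a step of about an at least 3.3-fold lower number from compound 3 to compound 4 (0.52 log units; beyond the scatter), with an estimated value of 60000 nM, and a range from 15000 nM to 200000 nM is expected to cover it.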

Compound 4, half-maximal inhibitory concentration: > 200000 nM
Compound 4 was reported as a limit (the forecaster's own chance of this, stated with the estimate: 30%); middle value at least 3.3-fold (0.52 log units) from the limit.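

Compound 4 gives only a limit in this assay, > 200000 nM, and compound 3 also sits at a limit, so no step can be read between compound 3 and compound 4: the limit of > 200000 nM in this assay, at which 3 of the 4 values shown sit.

Whether chloro in place of amino on an aromatic carbon changes the number at all on the core of compound 3 stays open, as the compounds shown bound this change only on the core of compound 1.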